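The source may hold more compounds than are shown below. What is called first, only, known or untested is meant among the compounds shown, and "the series" means these compounds.

Three compounds share one core. Compound 1 `CCn1c(=O)c2nc(-c3cccc(S(=O)(=O)O)c3)[nH]c2n(CC)c1=O` gives 8420 nM in an assay for binding affinity to adenosine receptor A1 (Bos taurus); a lower number here means a stronger inhibitor, a higher number a weaker inhibitor. Compound 2 `COc1cc(OC)cc(-c2nc3c(=O)n(C)c(=O)n(C)c3[nH]2)c1` gives 500 nM in this assay, and compound 3 `CCc1ccc(-c2nc3c(=O)n(C)c(=O)n(C)c3[nH]2)cc1` gives 0.8 nM. Compound 3 thus stands lowest of the three numbers, with compound 2 nearest and compound 1 furthest, both well beyond the scatter.

Compound 4 `CCOc1ccc(-c2nc3c(=O)n(C)c(=O)n(C)c3[nH]2)cc1` has not been measured. It differs from compound 3 as follows: ethoxy in place of ethyl on an aromatic carbon. Among the measured compounds shown here, no measured pair shows this change, so its effect can only be guessed. A modest step toward a higher number is expected, as a 6.3-fold higher number from compound 3 to compound 4 (0.80 log units; beyond the scatter), though a step within the scatter cannot be ruled out. Compound 4 is therefore expected to give about 5 nM in this assay, within a range from 1 nM to 30 nM.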

Compound 4, half-maximal inhibitory concentration: 2 nM
Compound 4: middle estimate off by 2.5-fold (0.40 log units), on the high side, and the stated range covers the measured number.
By their numbers in this assay, from the lowest: compound 3; then compound 4; then compound 2; then compound 1.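

On an aromatic carbon para to a large group, ethoxy in place of ethyl gives a 2.5-fold higher number from compound 3 to compound 4 (0.40 log units; beyond the scatter) in this assay, so this is a modest cost. The change adds an oxygen and one hydrogen-bond acceptor at this position, yet compound 4 at 2 nM keeps a low number. No measurement at hand accounts for the step. From the compounds shown here alone, whether the oxygen or the extra atom drives the step stays open, and so does the effect of an amine, a carboxylic acid or a longer chain such as propoxy here.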